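The compounds below may be only part of what the source reports. "The series", "measured", "known", "first", "only" and "open" are said of these compounds alone.

Of the compounds shown here, two have so far been measured in a functional assay on A549 cells (Homo sapiens) for inhibition, read by sulforhodamine B assay; a lower number here means that less compound is tolerated, a higher number that more compound is tolerated. Compound 1 `CC1(C)CCC[C@]2(C)[C@@H](/C=C/C3=CC(=O)OC3)C(CO)=C(O)C(=O)[C@@H]12` gives 48700 nM, and compound 2 `C=C1CC[C@H]2C(C)(C)CCC[C@]2(C)[C@H]1C/C=C1/CC(O)OC1=O` gives 14000 nM, the lowest of the two numbers, with compound 1 standing at a higher number by a gap beyond the usual scatter. Compound 3 `C=C1CC[C@H]2C(C)(C)CCC[C@]2(C)[C@H]1C/C=C1/CC(OC)OC1=O` differs from compound 2 in one place: methyl in place of hydrogen on an oxygen on a saturated carbon. Among the compounds with values here, no step between measured compounds bears on this change, so only a small shift in this assay is expected, in no firm direction, most likely none beyond the scatter. Compound 3 is therefore estimated at 17000 nM, with a range from 7000 nM to 40000 nM, which means an expected step of a 1.2-fold higher number from compound 2 to compound 3 (0.08 log units; within the scatter).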

Compound 3, concentration lethal to 50% of the cells: 71300 nM
Compound 3: the middle estimate sits 4.2-fold (0.62 log units) below what was measured, and the stated range ends below it.
By their numbers in this assay, from the lowest: compound 2; then compounds 1 and 3 (each within the scatter of the next).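

In this assay, the change from hydroxy to methoxy on this saturated carbon is not silent: it brings a 5.1-fold higher number from compound 2 to compound 3 (0.71 log units; beyond the scatter), so a single added methyl on this oxygen is enough to move the number beyond the scatter. No measurement here accounts for the shift. The compounds shown leave open whether the size of the group on this oxygen sets the number, as only hydrogen and methyl stand there. An ethyl or acetyl group on the same oxygen, or an amine in place of the hydroxy, would bear on that.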